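Series notes: from compound 1 to compound 4

The source may report more compounds than this note shows. Statements on the series, on what has been measured and on what is new or still open speak of the compounds shown alone.

Compound 1 `C=CCOc1ccc2c(=O)c(-c3cc(OC)c(OC)cc3OC)coc2c1` carries the allyloxy group on the shared core. In a functional assay on HepG2 cells (Homo sapiens) for antiproliferative activity, read by MTT assay, with a stated time of 24 h (on this read-out lower numbers stand for stronger inhibition and higher numbers for weaker inhibition), compound 1 gives 3450 nM, the highest number among the three measured compounds. In this assay compound 2 `COc1cc(OC)c(-c2coc3cc(OCc4ccccc4F)ccc3c2=O)cc1OC` gives 1280 nM, and compound 3 `COc1cc(OC)c(-c2coc3cc(OCc4ccc(Cl)cc4)ccc3c2=O)cc1OC` gives 940 nM. The step of a 2.7-fold lower number from compound 1 to compound 2 (0.43 log units; beyond the scatter) and the step of a 3.7-fold lower number from compound 1 to compound 3 (0.56 log units; beyond the scatter) both lower the number beyond the scatter, while the step of a 1.4-fold lower number from compound 2 to compound 3 (0.13 log units; within the scatter) stays within it, so the two measured aryl groups cannot be told apart on this read-out.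

Compound 4 `COc1cc(OC)c(-c2coc3cc(OCc4ccccc4Cl)ccc3c2=O)cc1OC` differs from compound 1 by 2-chlorophenyl in place of vinyl on a saturated chain carbon bound to an oxygen on an aromatic ring. Going by the values given here, the two steps that bear on this change, the one to the 2-fluorophenyl compound and the one to the 4-chlorophenyl compound, point the same way and are modest in size, so a lowering of similar size is expected, a 3.1-fold lower number from compound 1 to compound 4 (0.50 log units; beyond the scatter). The estimate for compound 4 in this assay is 1100 nM, with an expected range from 550 nM to 2200 nM.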

Compound 4, half-maximal inhibitory concentration: 1690 nM
The estimate for compound 4 lay 1.5-fold (0.19 log units) below the measured number; low and high end bracket the measured number.
By their numbers in this assay, from the lowest: compounds 3, 2 and 4 (each within the scatter of the next); then compound 1.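

In this assay, the 2-chlorophenyl group also keeps the number down relative to vinyl, a 2.0-fold lower number from compound 1 to compound 4 (0.31 log units; beyond the scatter), so all three halogenated aryl groups at this position differ from vinyl beyond the scatter, although this step is the smallest of the three. The change from 4-chlorophenyl to 2-chlorophenyl, a 1.8-fold higher number from compound 3 to compound 4 (0.25 log units; within the scatter), and the change from fluoro to chloro on an aromatic carbon, a 1.3-fold higher number from compound 2 to compound 4 (0.12 log units; within the scatter), both stay within the scatter, so neither the place of the chlorine nor the identity of the halogen can be resolved on this read-out. No measurement bears on why these aryl groups differ from vinyl.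

The compounds shown leave open whether the halogen contributes at all, since a plain phenyl group does not appear among them. They also leave open how a methoxy group on that ring, or a longer chain ending in an amine, would compare.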